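Working notes: 4-fluorophenyl to 3-fluorophenyl on the carbonyl

The source may hold more compounds than are shown below. What is called first, only, known or untested is meant among the compounds shown, and "the series" means these compounds.

Measured in a functional assay on Ehrlich cells (Mus musculus) for cytotoxicity, read by LDH release, with a stated time of 48 h; a lower number here means a stronger inhibitor, a higher number a weaker inhibitor:
- compound 1 `COc1ccc(-c2csc(NC(=O)COc3ccc(C(=O)c4ccc(C)cc4)cc3C)n2)cc1`: 20900 nM
- compound 2 `COc1ccc(-c2csc(NC(=O)COc3ccc(C(=O)c4ccc(F)cc4)cc3C)n2)cc1`: 5800 nM

Compound 2 holds the lower of the two numbers, at 5800 nM. Still unmeasured is compound 3 `COc1ccc(-c2csc(NC(=O)COc3ccc(C(=O)c4cccc(F)c4)cc3C)n2)cc1`, which carries 3-fluorophenyl in place of 4-fluorophenyl on a carbonyl carbon.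

Among the measured compounds shown here, one measured step bears on this change, and only loosely: a 3.6-fold lower number from compound 1 to compound 2 (0.56 log units; beyond the scatter). That modest step swapped methyl for fluoro on an aromatic carbon. For the measured compounds named here, no measured pair moves the fluoro group, so the data fix no direction for compound 3. In this assay, a shift no larger than that modest step is expected, most likely none beyond the scatter. The expected step is a 1.2-fold higher number from compound 2 to compound 3 (0.08 log units; within the scatter). The estimate for compound 3 is 7000 nM, with an expected range of 2800 nM to 17000 nM.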

Compound 3, half-maximal inhibitory concentration: 30900 nM
For compound 3 the middle estimate is 4.4-fold (0.64 log units) below the measured one, outside the stated range (above it).
By their numbers in this assay, from the lowest: compound 2; then compounds 1 and 3 (each within the scatter of the next).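

In this assay, the number at this carbonyl carbon depends on where the fluoro group sits on the phenyl ring, not only on which atoms are present: 3-fluorophenyl in place of 4-fluorophenyl, with the same atoms, gives a 5.3-fold higher number from compound 2 to compound 3 (0.73 log units; beyond the scatter). The other new step, a 1.5-fold higher number from compound 1 to compound 3 (0.17 log units; within the scatter), leaves 3-fluorophenyl and 4-methylphenyl level in this assay, so among the three groups shown, only 4-fluorophenyl stands apart. Nothing available accounts for this difference.

From the compounds shown here alone, whether 4-chlorophenyl or 4-methoxyphenyl on the carbonyl carbon would keep the number of compound 2 remains open. So does whether 3-methylphenyl would track 3-fluorophenyl, or whether the same step would recur with a different group in place of the methoxy group on the core.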